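Mirror Images at the Assay's Limit

A few compounds are considered here, and "the series" means these few. Any claim that something is new, unique, unknown or untested is made for them only; others in the source may bear on it.

- compound 1 `O=c1ccn(C2C=C(F)C(CO)O2)c(=O)[nH]1`: > 100000 nM
- compound 2 `Nc1nc(=O)n([C@H]2C=C(F)[C@@H](CO)O2)cc1F`: > 100000 nM

Both compounds were tested in a functional assay on CCRF-CEM cells (Homo sapiens) for cytotoxicity; a lower number here means a stronger inhibitor, a higher number a weaker inhibitor. Compound 2 reads > 100000 nM, which is a limit of the assay and not a number. Compound 1 reads > 100000 nM, which is also a limit. Together they make up (the limit of > 100000 nM in this assay, at which 2 of the 2 values shown sit), so neither compound gives a measured potency, and no step between measured compounds exists to learn from.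

The next compound is compound 3 `Nc1nc(=O)n([C@@H]2C=C(F)[C@H](CO)O2)cc1F`. Its relation to compound 2 is simple to state: the two compounds have the same atoms and bonds and differ only in configuration as drawn: 2 of 2 stereo elements differ (all stereocentres are inverted: mirror images); a stereocentre at a saturated ring carbon is drawn R in compound 2 and S in compound 3; a stereocentre at a saturated ring carbon is drawn R in compound 2 and S in compound 3. Nothing is added or removed, so any change in this assay would come from the handedness of the molecule alone. Mirror images can behave differently in living cells, so a measurable value cannot be ruled out. Even so, the likeliest result is another limit, and any number that does appear should lie close to it. The expected step is small and towards stronger inhibition, an at least 1.4-fold lower number from compound 2 to compound 3 (0.15 log units; that floor lies within the scatter). For compound 3 the estimated value is 70000 nM, with an expected range from 20000 nM to 100000 nM.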

Compound 3, half-maximal inhibitory concentration: > 100000 nM
Compound 3 was reported as a limit; the forecaster's own chance of this, stated with the estimate: 60%; middle value at least 1.4-fold (0.15 log units) from the limit.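

No step can be read between the mirror images compound 2 and compound 3, because both readings are limits of the assay and not numbers: the limit of > 100000 nM in this assay, at which 3 of the 3 values shown sit.

The compounds shown leave open whether either mirror image has any measurable potency in this assay, and so whether handedness changes the result there at all.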